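Swapping the para substituent: methoxy to chloro

The source may report more compounds than this note shows. Statements on the series, on what has been measured and on what is new or still open speak of the compounds shown alone.

In a functional assay on cells (Cancer cell lines, Homo sapiens) for cytotoxicity, read by sulforhodamine B assay, with a stated time of 48 h (on this read-out higher numbers stand for weaker inhibition of growth and lower numbers for stronger inhibition of growth), compound 1 `O=C1N=C(N2N=C(c3ccccc3)CC2c2ccccc2O)S/C1=C1/C(=O)Nc2ccccc21` gives 5370 nM. Compound 2 `COc1ccc(C2CC(c3ccccc3)=NN2C2=NC(=O)/C(=C3\C(=O)Nc4ccccc43)S2)cc1` carries a 4-methoxyphenyl in place of the 2-hydroxyphenyl of compound 1 and in this assay compound 2 gives 3450 nM; the shift a 1.6-fold lower number from compound 1 to compound 2 (0.19 log units; within the scatter) stays within the scatter, so the two numbers cannot be told apart, and compound 2 stands beside compound 1 as the only other measured point.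

Compound 3 `O=C1N=C(N2N=C(c3ccccc3)CC2c2ccc(Cl)cc2)S/C1=C1/C(=O)Nc2ccccc21` differs from compound 2 by chloro in place of methoxy on an aromatic carbon. Among the compounds with values here, the only step that bears on this position is the one from compound 1 to compound 2, which altered the group on the same phenyl and gave no movement beyond the scatter. The expected step in this assay for compound 3 is therefore a 1.0-fold higher number from compound 2 to compound 3 (0.01 log units; within the scatter), in no clear direction. For compound 3 the estimate in this assay is 3500 nM, expected to fall between 1500 nM and 8000 nM.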

Compound 3, concentration for total growth inhibition: 500 nM
For compound 3 the middle estimate is 7.0-fold (0.85 log units) above the measured one; measured number below the stated range.
By their numbers in this assay, from the lowest: compound 3; then compounds 2 and 1 (each within the scatter of the next).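

In this assay the aromatic group on the saturated ring carbon proves able to move the number after all: chloro in place of methoxy on the aromatic carbon gives a 6.9-fold lower number from compound 2 to compound 3 (0.84 log units; beyond the scatter) and so a step that the earlier pair, lying within the scatter, gave no sign of. The 4-chlorophenyl also stands clear of the 2-hydroxyphenyl, with an 11-fold lower number from compound 1 to compound 3 (1.03 log units; beyond the scatter) in the same assay, which leaves compound 3 with the lowest number of the three. Nothing at hand accounts for the size of these steps.

The compounds shown leave open whether this drop is particular to chloro or would also appear with a bromo, a nitrile or an amine on that aromatic carbon. They also leave open whether chloro elsewhere on the same phenyl would give a similar number.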